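A few compounds are considered here, and "the series" means these few. Any claim that something is new, unique, unknown or untested is made for them only; others in the source may bear on it.

Measured compounds in a functional assay on MCF7 cells (Homo sapiens) for antiproliferative activity, read by MTT assay, with a stated time of 48 h; on this read-out lower numbers stand for stronger inhibition and higher numbers for weaker inhibition:
compound 1, `COc1ccc(-n2cc(COc3ccc(/C=C/C(C)=O)cc3OC)nn2)cc1`, gives 33700 nM.
compound 2, `COc1cc(/C=C/C(C)=O)ccc1OCc1cn(-c2ccc(NC(=O)c3ccccc3)cc2)nn1`, gives 86700 nM.
compound 3, `COc1cc(/C=C/C(C)=O)ccc1OCc1cn(-c2ccc([N+](=O)[O-])cc2)nn1`, gives only a limit, > 100000 nM.

Within the data shown here, compound 3 therefore stands at the edge of what this assay reports: its result is a limit and not a number, the one value of the three that sits at the limit of > 100000 nM in this assay, at which 1 of the 3 values shown sits. The two steps that arrive at compound 3 run an at least 2.9-fold higher number from compound 1 to compound 3 (0.47 log units; beyond the scatter) and an at least 1.1-fold higher number from compound 2 to compound 3 (0.06 log units; that floor lies within the scatter); putting the nitro group on this position has so far given a weaker result or one indistinguishable from its neighbour.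

Compound 4, `CCOC(=O)c1ccc(-n2cc(COc3ccc(/C=C/C(C)=O)cc3OC)nn2)cc1`, differs from compound 3 in a single place: ethoxycarbonyl in place of nitro on an aromatic carbon. Since the nitro group leaves again, the same two steps bear on this change, read in reverse. Removing the nitro is expected to bring the number back toward those of compound 1 and compound 2, so the expected step is an at least 1.6-fold lower number from compound 3 to compound 4 (0.22 log units; that floor lies within the scatter). Compound 4 is thus estimated at 60000 nM, with a likely range from 20000 nM to 150000 nM.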

Compound 4, half-maximal inhibitory concentration: > 100000 nM
Compound 4 was reported as a limit; the forecaster's own chance of this, stated with the estimate: 35%; middle value at least 1.6-fold (0.22 log units) from the limit.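

Ethoxycarbonyl on this aromatic carbon, like nitro, ends in a limit and not a number: the limit of > 100000 nM in this assay, at which 2 of the 4 values shown sit. Set against the methoxy group, the change gives an at least 2.9-fold higher number from compound 1 to compound 4 (0.47 log units; beyond the scatter), so compound 1 keeps the lowest number of the four in this assay. Set against the benzamido group, it gives an at least 1.1-fold higher number from compound 2 to compound 4 (0.06 log units; that floor lies within the scatter), which does not separate the two, while compound 3 and compound 4 are both limits and the step between them cannot be read.

The compounds shown leave open how an amine, a carboxylic acid or a plain methyl group on this aromatic carbon would read, and whether any group there can give a lower number than compound 1. They also leave open how far compound 3 and compound 4 lie past their limits.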